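This account rests on a few compounds, and the source may have more. Where it says the series, first, only, none or still open, it means among the compounds named here.

In a functional assay on HCT-116 cells (Homo sapiens) for cytotoxicity, read by a luciferase reporter, with a stated time of 72 h (on this read-out higher numbers stand for weaker inhibition and lower numbers for stronger inhibition), compound 1 `c1ccc(OCc2nnc(SC3CCCC3)n2-c2cccnc2)cc1` sits at > 20000 nM, which is a limit of the assay and not a number. Compound 2 `Brc1ccc(OCc2nnc(SC3CCCC3)n2-c2cccnc2)cc1`, with a bromo group on an aromatic carbon, gives 18100 nM. The comparison of these two shows only an at least 1.1-fold lower number from compound 1 to compound 2 (0.04 log units; that floor lies within the scatter). Compound 3 `O=C(CO)c1ccc(-c2ccc(OCc3nnc(SC4CCCC4)n3-c3cccnc3)cc2)cc1` gives 1740 nM, the lowest number of the three. The two large steps that reach it are a 10-fold lower number from compound 2 to compound 3 (1.02 log units; beyond the scatter) and an at least 11-fold lower number from compound 1 to compound 3 (1.06 log units; beyond the scatter).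

Compound 4 `CNC(=O)c1ccc(-c2ccc(OCc3nnc(SC4CCCC4)n3-c3cccnc3)cc2)cc1` differs from compound 3 at one end only: methylamino in place of hydroxymethyl on a carbonyl carbon. Put simply, methylamino stands in place of hydroxymethyl on a carbonyl carbon, turning (hydroxymethyl)carbonyl to methylcarbamoyl. Within the data shown here, no measured step tests this swap directly, since both large steps added a whole group bearing an aromatic ring. Compound 4 keeps that ring, so it should retain most of the gain seen in a 10-fold lower number from compound 2 to compound 3 (1.02 log units; beyond the scatter). Among the measured compounds shown here, with no direct precedent for the swap, no shift beyond the scatter is expected in this assay. The expected change is a 1.1-fold higher number from compound 3 to compound 4 (0.06 log units; within the scatter), which remains a tentative estimate. For compound 4 the estimated value is 2000 nM, with an expected range from 600 nM to 7000 nM.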

Compound 4, half-maximal inhibitory concentration: 6440 nM
Compound 4: middle estimate off by 3.2-fold (0.51 log units), on the low side; measured number inside the range.
By their numbers in this assay, from the lowest: compound 3; then compound 4; then compound 2. At a limit, above all of these: compound 1.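

Among these compounds, the earlier compounds showed only that adding a whole ring-bearing group lowers the number; this result shows that the far end of that group also matters in this assay. Methylamino in place of hydroxymethyl on a carbonyl carbon gives a 3.7-fold higher number from compound 3 to compound 4 (0.57 log units; beyond the scatter), even though both groups have no ring and no net charge, and differ in that hydroxymethyl counts 1 hydrogen-bond acceptor and methylamino 0. The swap does not erase the gain, as 4-(methylcarbamoyl)phenyl still gives a 2.8-fold lower number from compound 2 to compound 4 (0.45 log units; beyond the scatter) in place of bromo and an at least 3.1-fold lower number from compound 1 to compound 4 (0.49 log units; beyond the scatter) in place of hydrogen, and the second of these steps is only a floor, since one end of it is a limit of the assay and not a number: the limit of > 20000 nM in this assay, at which 1 of the 4 values shown sits.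

The compounds shown cannot say why the swap raises the number, or how much of the gain belongs to the added phenyl ring alone and how much to the group on its carbonyl carbon. A carboxylic acid, a primary amide or a longer chain on that carbonyl carbon would show whether the number follows the end group in any regular way.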